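A few compounds are considered here, and "the series" means these few. Any claim that something is new, unique, unknown or untested is made for them only; others in the source may bear on it.

Working notes on the series. Three members have been measured: compound 1 `CC(c1ccc(-c2ccccc2)c(F)c1)c1nnc2n1N=C(c1ccc(Cl)cc1)CS2`, compound 2 `COc1ccc2cc(C(C)c3nnc4n3N=C(c3ccc([N+](=O)[O-])cc3)CS4)ccc2c1` and compound 3 `CC(C)Cc1ccc(C(C)c2nnc3n2N=C(c2ccc(F)cc2)CS3)cc1`. In a functional assay on Huh-7 cells (Homo sapiens) for inhibition, read by sulforhodamine B assay, with a stated time of 72 h (on this read-out lower numbers stand for stronger inhibition and higher numbers for weaker inhibition), compound 1 gives 3900 nM, compound 2 gives 14700 nM and compound 3 gives 7800 nM. No pair among these three differs in a single place, so only the raw numbers can be compared: the value of compound 3 lies within the scatter of both compound 1 and compound 2, and no order can be drawn among them. Compound 4 `CC(C)Cc1ccc(C(C)c2nnc3n2N=C(c2ccc(Cl)cc2Cl)CS3)cc1` is not yet measured; it differs from compound 3 by 2,4-dichlorophenyl in place of 4-fluorophenyl on a carbon with a double bond to nitrogen. Among the measured compounds shown here, no measured step covers this change, so in this assay no shift beyond the scatter is expected. The value of compound 4 is estimated at 6000 nM, within a range of 2500 nM to 15000 nM. This expected change amounts to a step of a 1.3-fold lower number from compound 3 to compound 4 (0.11 log units; within the scatter).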

Compound 4, half-maximal inhibitory concentration: 7500 nM
Estimate against measurement, compound 4: 1.3-fold (0.10 log units) below; the measured number falls inside the stated range.
By their numbers in this assay, from the lowest: compounds 1, 4, 3 and 2 (each within the scatter of the next, the first and the last beyond it).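

Among the compounds shown here, this is the first single-place step: on a carbon with a double bond to nitrogen, 2,4-dichlorophenyl in place of 4-fluorophenyl gives a 1.0-fold lower number from compound 3 to compound 4 (0.02 log units; within the scatter) in this assay. At this position, then, exchanging these two halogen-bearing phenyl groups leaves the number within the scatter, at least on the core of compound 3. The data shown offer no evidence bearing on why this is so.

On these data alone, whether an amine or a carboxylic acid on this phenyl ring would shift the number remains open. So does whether the same exchange behaves alike on the cores of compound 1 and compound 2.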